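From 3-bromophenyl to 4-methoxyphenyl: expected step in compound 4

The source may hold more compounds than are shown below. What is called first, only, known or untested is meant among the compounds shown, and "the series" means these compounds.

In a functional assay on the whole organism (strain Kunming) with Mus musculus as the target, with a stated time of 0.5 h (on this read-out higher numbers stand for an effect only at larger amounts of compound and lower numbers for an effect already at smaller amounts), compound 1 (`COc1cc(OC)c(OC)cc1/C=C/COC(=O)/C=C/c1ccc(OC)c(OC)c1`) gives 58.1 mg/kg and compound 2 (`COc1cc(OC)c(OC)cc1/C=C/COC(=O)/C=C/c1cc(OC)c(OC)c(OC)c1`) gives 33.2 mg/kg on the shared core. Compound 3 (`COc1cc(OC)c(OC)cc1/C=C/COC(=O)/C=C/c1cccc(Br)c1`) reads 75.7 mg/kg and lies within the scatter of compound 1, while its number stands above that of compound 2 by a gap beyond the scatter.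

Compound 4 (`COc1ccc(/C=C/C(=O)OC/C=C/c2cc(OC)c(OC)cc2OC)cc1`) is still unmeasured. It carries 4-methoxyphenyl in place of 3-bromophenyl on a double-bonded chain carbon bound to a double-bonded chain carbon.

Going by the values given here, two measured steps bear on this change. Among the compounds with values here, putting 3-bromophenyl in place of 3,4-dimethoxyphenyl at that same place gave a 1.3-fold higher number from compound 1 to compound 3 (0.11 log units; within the scatter) as the closest precedent. Methoxy in place of hydrogen on an aromatic carbon gave a 1.8-fold lower number from compound 1 to compound 2 (0.24 log units; within the scatter) as the second precedent. Neither step leaves the scatter, so no step beyond it is expected in this assay for the present change, and any drift is tentatively expected toward a lower number. The expected step is a 1.3-fold lower number from compound 3 to compound 4 (0.10 log units; within the scatter) and would not be distinguishable from repeat variation. The estimate for compound 4 is 60 mg/kg with an expected range from 32 mg/kg to 110 mg/kg in repeat measurements.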

Compound 4, dose for half-maximal effect: 70.6 mg/kg
Estimate against measurement, compound 4: 1.2-fold (0.07 log units) below; the measured number falls inside the stated range.
By their numbers in this assay, from the lowest: compounds 2, 1, 4 and 3 (each within the scatter of the next, the first and the last beyond it).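

In this assay, 4-methoxyphenyl in place of 3-bromophenyl on a double-bonded chain carbon bound to a double-bonded chain carbon gives a 1.1-fold lower number from compound 3 to compound 4 (0.03 log units; within the scatter), so this place takes either group without a step beyond the scatter, even though one group carries bromine and the other a methoxy oxygen. Hydrogen in place of methoxy on an aromatic carbon gives a 1.2-fold higher number from compound 1 to compound 4 (0.08 log units; within the scatter), and with the earlier step of methoxy in place of hydrogen, a 1.8-fold lower number from compound 1 to compound 2 (0.24 log units; within the scatter), removing or adding a single methoxy on this aromatic ring now stays within the scatter in both directions. The data at hand offer no independent measurement that could account for these small steps.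

Going by these compounds alone, whether an amine or a carboxylic acid on this phenyl ring would move the number beyond the scatter remains open, as every substituent at this place so far is a methoxy or a bromine. From the compounds shown here alone, all four compounds also carry the same ester on the shared core, so the effect of an amide at that link remains open too.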